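Swapping the aryl group on the shared core of compound 2

A few compounds are considered here, and "the series" means these few. Any claim that something is new, unique, unknown or untested is made for them only; others in the source may bear on it.

Compound 2 `Cc1oc(-c2c(C)c(C)c(C)c(C)c2C)nc1CN1CCC(C(=O)NCCCN2C[C@H](C)C[C@H](C)C2)CC1` sits in the middle of the three measured compounds. In a physicochemical assay for permeability, using PAMPA (a lower number here means that the compound crosses the layer more slowly, a higher number that the compound crosses the layer faster), compound 2 gives 455 10^-6 cm/s. Compound 3 `Cc1ccccc1-c1nc(CN2CCC(C(=O)NCCCN3CCC(C)CC3)CC2)c(C)o1` gives 425 10^-6 cm/s in this assay, a value within the scatter of compound 2. Compound 1 `CC[C@@H]1C[C@H](CC)CN(CCCNC(=O)C2CCN(Cc3nc(-c4ccccc4C)oc3C)CC2)C1` gives 1270 10^-6 cm/s in this assay, so compound 2 stands well under it. Among the compounds with values here, the only single-place step among the measured compounds is a 3.0-fold lower number from compound 1 to compound 3 (0.48 log units; beyond the scatter), and it concerns the piperidine end of the chain, not the aryl group.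

Compound 4 `COc1cccc(Cl)c1-c1nc(CN2CCC(C(=O)NCCCN3C[C@H](C)C[C@H](C)C3)CC2)c(C)o1` differs from compound 2 at the other end of the molecule: 2-chloro-6-methoxyphenyl in place of 2,3,4,5,6-pentamethylphenyl on an aromatic carbon. Within the data shown here, no measured step touches this position, so the expectation for compound 4 rests on the spread of the values of compound 2 and compound 3 alone. The step is expected to be small, a 1.2-fold lower number from compound 2 to compound 4 (0.08 log units; within the scatter), lying within the scatter. In this assay compound 4 is estimated at 380 10^-6 cm/s, with a range from 180 10^-6 cm/s to 750 10^-6 cm/s.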

Compound 4, apparent permeability: 51 10^-6 cm/s
Beside the measured number, compound 4's estimate is 7.5-fold (0.87 log units) above it, outside the stated range (below it).
By their numbers in this assay, from the lowest: compound 4; then compounds 3 and 2 (each within the scatter of the next); then compound 1.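

In this assay, the aryl group on the shared core proves to be a position that matters: 2-chloro-6-methoxyphenyl in place of 2,3,4,5,6-pentamethylphenyl gives an 8.9-fold lower number from compound 2 to compound 4 (0.95 log units; beyond the scatter) on this core. Within the data shown here, until now the only readable step was at the piperidine end of the chain, so this is the first sign that the far end of the molecule also moves the number. The entering group has fewer heavy atoms and adds a hydrogen-bond acceptor, but nothing measured accounts for the step.

As far as these compounds go, it stays open whether the chlorine or the methoxy carries the step, which a 2-chlorophenyl or a 2-methoxyphenyl group on the same core would separate. Also open, from the compounds shown here alone, is whether the step holds with a 3,5-diethylpiperidin-1-yl group at the chain end.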